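This account rests on a few compounds, and the source may have more. Where it says the series, first, only, none or still open, it means among the compounds named here.

Measured to date in a functional assay on CHO cells for agonist activity at Alpha-2B adrenergic receptor (Homo sapiens); a lower number here means a smaller maximal response, a higher number a larger maximal response:

compound 1 `CC(Oc1ccccc1-c1ccccc1[N+](=O)[O-])C1=NCCN1` gives < 0.3, a limit of this assay and not a number.
compound 2 `CC(Oc1ccccc1-c1ccccc1)C1=NCCO1` gives < 0.3, likewise a limit.
compound 3 `CC(Oc1ccccc1-c1ccccc1)C1=NCCS1` gives < 0.3, likewise a limit.

All three shown values sit at the same limit, (the limit of < 0.3 in this assay, at which 3 of the 3 values shown sit), so compound 1 stands at a limit in this assay and no number for it is known. Among the compounds with values here, the only single-point step among the measured compounds, a step that the two limits leave unreadable from compound 2 to compound 3, is unreadable because both ends are limits; it carries no information on the size of any step.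

Compound 4 `CC(Oc1ccccc1-c1ccccc1O)C1=NCCN1` differs from compound 1 at one place: hydroxy in place of nitro on an aromatic carbon. Within the data shown here, no measured step touches this kind of change, and no measured step in the set has a readable size at all. Nothing in the measured compounds therefore supports an expectation of a move in either direction beyond the scatter; the one thing shared by all three, (the limit of < 0.3 in this assay, at which 3 of the 3 values shown sit), favours compound 4 again reaching at most a small maximal response, most likely again reported only as a limit.

The estimate for compound 4 in this assay is 0.2, with a range from 0 to 0.5. The step that this estimate means, a step that the limit leaves unreadable from compound 1 to compound 4, is expected to stay within the scatter of the limits shown.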

Compound 4, intrinsic activity: the largest response reached, as a fraction of the reference agonist's: < 0.3
Compound 4 gave a limit, no number; the forecaster's own chance of this, stated with the estimate: 70%; the middle value is on the limit's open side.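

In this assay compound 4 gives < 0.3 as a limit and not a number. Within the data shown here, compound 1 also stands only at a limit, so no step between compound 1 and compound 4 can be read. The compounds shown leave open whether hydroxy in place of nitro on an aromatic carbon changes the maximal response at all, with every value at one limit: the limit of < 0.3 in this assay, at which 4 of the 4 values shown sit.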